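Compound 3 in cytotoxicity: methoxy for methyl

The compounds below may be only part of what the source reports. "The series", "measured", "known", "first", "only" and "open" are said of these compounds alone.

Measured so far, in an ADME assay on Vero cells (Chlorocebus sabaeus) for cytotoxicity, with a stated time of 72 h; on this read-out higher numbers stand for lower toxicity in this test and lower numbers for higher toxicity in this test:
- compound 1 `COc1ccc(/C=N/NC(=O)c2cnccn2)cc1` gives > 30 ug/mL, which is a limit of the assay and not a number.
- compound 2 `Cc1ccc2nc(Cl)c(/C=N/NC(=O)c3cnccn3)cc2c1` gives > 30 ug/mL, again a limit and not a number.

Among the compounds with values here, compound 2 therefore stands at no number at all in this assay, only at a limit, and the one further value shown is a limit as well, namely (the limit of > 30 ug/mL in this assay, at which 2 of the 2 values shown sit). Within the data shown here, no step between measured compounds is available, so nothing in the data sets a size or direction for the change at hand.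

Compound 3 `COc1ccc2nc(Cl)c(/C=N/NC(=O)c3cnccn3)cc2c1` differs from compound 2 by methoxy in place of methyl on an aromatic carbon. Because compound 2 sits at the limit of > 30 ug/mL in this assay, at which 2 of the 2 values shown sit, together with compound 1, compound 3 is expected to come out at a limit too rather than at a number. The estimated step from compound 2 to compound 3 is a step that the limit leaves unreadable from compound 2 to compound 3, that is, none beyond the scatter in this assay. Compound 3 is estimated at 40 ug/mL, expected to fall between 20 ug/mL and 100 ug/mL.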

Compound 3, half-maximal cytotoxic concentration: 5.37 ug/mL
Compound 3: middle estimate off by 7.4-fold (0.87 log units), on the high side, and the stated range ends above it.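

In this assay, the aromatic carbon that carries methyl in compound 2 proves sensitive to substitution: methoxy in place of methyl gives an at least 5.5-fold lower number from compound 2 to compound 3 (0.74 log units; beyond the scatter). Compound 2 gives > 30 ug/mL, which is a limit of the assay and not a number, so this step sets only a minimum size, and the full size of the change remains unreadable. Compound 3 is the first compound here to give a number rather than a limit, so this single change on the shared core is enough to bring the read-out into the measurable range, a shift the earlier compounds could not show, as both sat at the same limit: the limit of > 30 ug/mL in this assay, at which 2 of the 3 values shown sit.

The compounds shown do not separate the effect of the added oxygen from that of the added heavy atom, and ethyl, hydroxyl or an amine on the same aromatic carbon would help to tell these apart. Within the data shown here, whether this change would have a similar effect on other parts of the series also remains open, as this is the only step of its kind available.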